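The source may hold more compounds than are shown below. What is called first, only, known or untested is meant among the compounds shown, and "the series" means these compounds.

Measured so far:
compound 1 `COc1ccc(NC(=O)N2N=C(c3cc4ccccc4o3)CC2c2ccc(O)c(OC)c2)cc1` — in a functional assay on microsomes from liver (Rattus norvegicus, strain Wistar) for inhibition, with a stated time of 15 min (on this read-out higher numbers stand for weaker inhibition and lower numbers for stronger inhibition), compound 1 gives 29000000 nM
compound 2 `COc1cc(C2CC(c3cc4ccccc4o3)=NN2C(=O)Cl)ccc1O` — in this assay compound 2 gives 147000000 nM

Going by the values given here, compound 1 holds the lowest of the two numbers; the only other number is that of compound 2, reached by a 5.1-fold higher number from compound 1 to compound 2 (0.70 log units; beyond the scatter).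

Compound 3 `COc1cc(C2CC(c3cc4ccccc4o3)=NN2C(=O)Nc2cccc(O)c2)ccc1O` is not yet measured. It differs from compound 1 by 3-hydroxyphenyl in place of 4-methoxyphenyl on an amide-type nitrogen.

Among the compounds with values here, the single measured step, a 5.1-fold higher number from compound 1 to compound 2 (0.70 log units; beyond the scatter), concerns what sits on the carbonyl carbon, not the aryl group on the amide-type nitrogen, so it does not bear on the present change. Within the data shown here, no measured pair shows what exchanging one aryl group for another does in this assay. With nothing to point either way, the expectation for compound 3 is a step of no change at the digits printed from compound 1 to compound 3 (within the scatter) that stays within the usual scatter, with a wide range to allow for the unknown. Compound 3 is therefore estimated at 29000000 nM, between 8000000 nM and 100000000 nM.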

Compound 3, half-maximal inhibitory concentration: 24000000 nM
Compound 3: the middle estimate sits 1.2-fold (0.08 log units) above what was measured, within the range that was stated.
By their numbers in this assay, from the lowest: compounds 3 and 1 (each within the scatter of the next); then compound 2.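

In this assay, going by these compounds alone, exchanging one aryl group for another on the amide-type nitrogen gives a 1.2-fold lower number from compound 1 to compound 3 (0.08 log units; within the scatter), so 3-hydroxyphenyl in place of 4-methoxyphenyl produces no separation between this pair, even though the entering group brings a hydrogen-bond donor. On the carbonyl carbon, (3-hydroxyphenyl)amino in place of chloro gives a 6.1-fold lower number from compound 2 to compound 3 (0.79 log units; beyond the scatter), so the separation from compound 2 now appears with two different arylamino groups. Nothing available explains either step.

Compound 1 and compound 3 differ in both the oxygen substituent and its ring position, so 3-methoxyphenyl and 4-hydroxyphenyl would be needed to separate these two features. As far as these compounds go, it also remains open whether a non-aromatic group on the amide-type nitrogen, such as a butyl chain, or an aryl group carrying a carboxylic acid or an amine, would stay in this range.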